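The compounds below may be only part of what the source reports. "The series", "measured", "known", "first", "only" and "open" are said of these compounds alone.

Compound 1 `COc1ccc(-n2cnc3cnc(Oc4cccc(NC(C)=O)c4)cc32)cc1OC`: > 30000 nM
Compound 2 `COc1ccc(-n2cnc3cnc(-c4ccc(F)cc4C)cc32)cn1`: 70 nM

Of the compounds shown here, two have been measured in a functional assay on HL-60 cells (Homo sapiens) for activation, read by flow cytometry, with a stated time of 4 days; on this read-out lower numbers stand for an effect already at smaller amounts and higher numbers for an effect only at larger amounts of compound. Compound 1 gives only a limit there, > 30000 nM, and not a number; this is the limit described in the limit of > 30000 nM in this assay, at which 1 of the 2 values shown sits. Going by the values given here, compound 2 gives 70 nM in this assay, so it stands as the only compound with an actual number.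

The next compound, compound 3 `Cc1cc(F)ccc1-c1cc2c(cn1)ncn2CC1CC1`, has not yet been measured in this assay. It differs from compound 2 in one place: cyclopropylmethyl in place of 6-methoxypyridin-3-yl on an aromatic nitrogen. The group that leaves is aromatic and carries hydrogen-bond acceptors; the group that enters is a small non-aromatic ring on a short chain and carries none.

No step between measured compounds is available to guide the size of this change, and no cause for any measured value can be given. A loss beyond the scatter is expected, with a step of an 8.6-fold higher number from compound 2 to compound 3 (0.93 log units; beyond the scatter). Compound 3 is therefore estimated at 600 nM in this assay, within a range of 100 nM to 5000 nM.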

Compound 3, half-maximal effective concentration: > 30000 nM
Compound 3 ended at the assay's limit; the forecaster's own chance of this, stated with the estimate: 15%; middle value at least 50-fold (1.69 log units) from the limit.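

Placing cyclopropylmethyl instead of 6-methoxypyridin-3-yl on the aromatic nitrogen gives an at least 420-fold higher number from compound 2 to compound 3 (2.63 log units; beyond the scatter) in this assay, the first reading of what this position tolerates, and it shows that the measurable effect of compound 2 does not survive this change. The value of compound 3 is a limit and not a number, so the true size of the step stays unknown: the limit of > 30000 nM in this assay, at which 2 of the 3 values shown sit. This single step changes several things at once, as an aromatic ring carrying hydrogen-bond acceptors gives way to a small non-aromatic ring on a short chain, and the compounds shown do not separate these differences.

Going by these compounds, it remains open whether a plain phenyl or a pyridin-3-yl without the methoxy group would keep a number in this assay. A cyclohexyl ring on the same nitrogen would show whether a larger non-aromatic group fares any better than cyclopropylmethyl.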